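The compounds below may be only part of what the source reports. "The series", "measured", "known", "first", "only" and "open" are said of these compounds alone.

Measured so far in an ADME assay for permeability, using PAMPA, at pH 7.4; on this read-out lower numbers stand for lower permeability and higher numbers for higher permeability:
- compound 1 `Cc1cc(NC(=O)Nc2ccc(C)c(Cl)c2)c2ccccc2n1` gives 262 10^-6 cm/s
- compound 2 `Cc1cc(NC(=O)Nc2ccccc2OC(F)(F)F)c2ccccc2n1` gives 1110 10^-6 cm/s
- compound 3 `CSc1ccc(NC(=O)Nc2cc(C)nc3ccccc23)cc1` gives 473 10^-6 cm/s

These three compounds share a core and carry different groups on its outer aromatic ring. In this assay, compound 3 at 473 10^-6 cm/s lies within the usual scatter of compound 1 at 262 10^-6 cm/s, so these two values cannot be told apart. Compound 2 at 1110 10^-6 cm/s stands higher than compound 3, and that gap lies beyond the scatter.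

The next compound to be measured is compound 4 `COC(=O)c1ccc(NC(=O)Nc2cc(C)nc3ccccc23)cc1`. It has methoxycarbonyl in place of methylsulfanyl on an aromatic carbon, para to a large group (methoxycarbonyl in place of methylsulfanyl on an aromatic carbon).

Within the data shown here, no two measured compounds differ in one place only, so the data contain no direct guide to the size of this step. The expectation therefore starts from compound 3 at 473 10^-6 cm/s and leans slightly downward, as a judgement and not as a measured trend. The estimated change is small, probably not beyond the scatter, and is expected to be a 1.6-fold lower number from compound 3 to compound 4 (0.20 log units; within the scatter).

For compound 4 the estimated value is 300 10^-6 cm/s, with an expected range from 120 10^-6 cm/s to 700 10^-6 cm/s.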

Compound 4, apparent permeability: 448 10^-6 cm/s
The estimate for compound 4 lay 1.5-fold (0.17 log units) below the measured number; low and high end bracket the measured number.
By their numbers in this assay, from the lowest: compounds 1, 4 and 3 (each within the scatter of the next); then compound 2.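

Among these compounds, this is the first pair in the set that differs in one place only, so it gives the first direct look at this position. On an aromatic carbon para to a large group, methoxycarbonyl in place of methylsulfanyl gives a 1.1-fold lower number from compound 3 to compound 4 (0.02 log units; within the scatter) in this assay, so the two compounds cannot be told apart in this read-out, even though the entering group has 4 heavy atoms against 2 and 2 hydrogen-bond acceptors against 1. No measurement shown here explains why these two groups read alike.

As far as these compounds go, a single step at a single position cannot say how far this result reaches, so it remains open whether a carboxylic acid or an amine on the same aromatic carbon would also stay within the scatter of compound 3. From the compounds shown here alone, it is equally open whether methoxycarbonyl would give so small a step on a different carbon of this ring, or whether the same exchange would do so on a compound with a different core.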